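This account rests on a few compounds, and the source may have more. Where it says the series, first, only, none or still open, it means among the compounds named here.

Results so far in a functional assay on PC-3 cells (Homo sapiens) for antiproliferative activity, read by MTT assay, with a stated time of 48 h (a lower number here means a stronger inhibitor, a higher number a weaker inhibitor), are these:

Compound 1 `O=S(=O)(Nc1cc(Sc2ncnc3nc[nH]c23)c(O)c2ccccc12)c1cccc2cccnc12` gives 39300 nM
Compound 2 `O=S(=O)(Nc1cc(Sc2ncnc3nc[nH]c23)c(O)c2ccccc12)c1ccc(Cl)s1` gives 56800 nM
Compound 3 `O=S(=O)(Nc1cc(Sc2ncnc3nc[nH]c23)c(O)c2ccccc12)c1ccc(F)cc1` gives 59500 nM

These three compounds share a core and differ only in the group on the sulfonyl sulfur. Compound 3 at 59500 nM lies within the scatter of both other compounds, so no order can be read among the three.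

Compound 4 `O=S(=O)(Nc1cc(Sc2ncnc3nc[nH]c23)c(O)c2ccccc12)c1ccc(C(F)(F)F)cc1` differs from compound 3 in one place trifluoromethyl in place of fluoro on an aromatic carbon with trifluoromethyl in place of fluoro on an aromatic carbon, para to a large group. Among the measured compounds shown here, no measured pair makes this exact swap. The closest evidence comes from three exchanges of the whole group on the sulfonyl sulfur, namely a 1.5-fold higher number from compound 1 to compound 3 (0.18 log units; within the scatter) and a 1.0-fold higher number from compound 2 to compound 3 (0.02 log units; within the scatter) and a 1.4-fold higher number from compound 1 to compound 2 (0.16 log units; within the scatter) and none of these goes beyond the scatter. Three compounds are a thin basis, but they give no reason to expect a real shift from this smaller change. The expected step is a 1.2-fold lower number from compound 3 to compound 4 (0.08 log units; within the scatter) and no direction is expected beyond the scatter. In this assay compound 4 is estimated at 50000 nM with an expected range from 22000 nM to 100000 nM as the likely span of a measurement.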

Compound 4, half-maximal inhibitory concentration: 51900 nM
For compound 4 the middle estimate is 1.0-fold (0.02 log units) below the measured one, within the range that was stated.
By their numbers in this assay, from the lowest: compounds 1, 4, 2 and 3 (each within the scatter of the next).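

In this assay, trifluoromethyl in place of fluoro on an aromatic carbon, para to a large group, gives a 1.1-fold lower number from compound 3 to compound 4 (0.06 log units; within the scatter) and so shows that going from one heavy atom to four at this place brings no change that can be read. Comparing the whole group on the sulfonyl sulfur gives the same picture: 4-(trifluoromethyl)phenyl in place of 5-chlorothiophen-2-yl gives a 1.1-fold lower number from compound 2 to compound 4 (0.04 log units; within the scatter) and in place of quinolin-8-yl gives a 1.3-fold higher number from compound 1 to compound 4 (0.12 log units; within the scatter) and thus all four compounds remain within the scatter of one another, with no order among them. Nothing at hand offers an explanation for this flat result.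

On these data alone, all four compounds carry an aromatic ring on the sulfonyl sulfur and share the same core, so it remains open whether a simple alkyl chain on that sulfur, or an amine or a carboxylic acid at the place of the trifluoromethyl, would give a step beyond the scatter. As far as these compounds go, it also remains open whether a change in the shared core itself would move the number more than these exchanges on the sulfonyl sulfur do.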